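The source may hold more compounds than are shown below. What is called first, only, known or untested is meant among the compounds shown, and "the series" means these compounds.

Measured so far:
compound 1 `CC(C)c1nnc(-c2ccc(N3CCC(Oc4ccccc4C(F)(F)F)CC3)nn2)s1` — 8.8 nM
compound 2 `FC(F)(F)c1ccccc1OC1CCN(c2ccc(-c3nnco3)nn2)CC1` — 22 nM
compound 3 `COc1ccccc1OC1CCN(c2ccc(-n3ccnc3)nn2)CC1` — 543 nM

In an assay on microsomes from liver for inhibition of acyl-CoA desaturase 1 (Rattus norvegicus) (on this read-out higher numbers stand for weaker inhibition and lower numbers for stronger inhibition), compound 3 stands highest of the three numbers; compound 2 and compound 1 both give clearly lower numbers, beyond the scatter. The next compound is compound 4 `c1cc2c(c(OC3CCN(c4ccc(-n5ccnc5)nn4)CC3)c1)CCC2`, with the change (2,3-dihydro-1H-inden-4-yl in place of 2-methoxyphenyl on an oxygen on a saturated carbon). Going by the values given here, the only single-place step available, a 2.5-fold higher number from compound 1 to compound 2 (0.40 log units; beyond the scatter), concerns the heteroaryl on the core, not the aryl on the oxygen, so it does not bear on this change. Among the compounds with values here, compound 1 and compound 2 carry a different aryl on the oxygen, but they also differ from compound 3 in the heteroaryl, so no step isolates the aryl. For compound 4 the expected step is therefore a 1.6-fold lower number from compound 3 to compound 4 (0.19 log units; within the scatter), which stays within the scatter. Compound 4 is estimated at 350 nM, range 80 nM to 1500 nM.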

Compound 4, half-maximal inhibitory concentration: 10 nM
Compound 4: the middle estimate sits 35-fold (1.54 log units) above what was measured, outside the stated range (below it).
By their numbers in this assay, from the lowest: compounds 1 and 4 (each within the scatter of the next); then compound 2; then compound 3.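

Replacing 2-methoxyphenyl with 2,3-dihydro-1H-inden-4-yl on the oxygen gives a 54-fold lower number from compound 3 to compound 4 (1.73 log units; beyond the scatter) in this assay and shows that the aryl at this place can shift the number strongly. The entering group adds a five-membered non-aromatic ring and lacks the hydrogen-bond acceptor of the leaving group, and this single step cannot separate those two differences. No supporting measurement bears on the size of the step.

As far as these compounds go, whether 2,3-dihydro-1H-inden-4-yl keeps this effect alongside the heteroaryl of compound 1 or compound 2 remains open. Also open, from the compounds shown here alone, is how an amine or a carboxylic acid on that aryl would read.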